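Dropping the cyano group from compound 2

The compounds below may be only part of what the source reports. "The series", "measured", "known", "first", "only" and "open" are said of these compounds alone.

In an in vitro ADME assay on microsomes from liver (Homo sapiens) for metabolic stability (a higher number here means faster removal of the compound, a lower number slower removal), compound 1 (`COC(=O)[C@H]1CC[C@@H](n2/c(=N/C(=O)c3ccccc3)[nH]c3ccc(CN4CCCCC4)cc32)CC1`) gives 85 mL.min-1.g-1 and compound 2 (`CC(C)NC(=O)[C@H]1CC[C@@H](n2/c(=N/C(=O)c3cccc(C#N)c3)[nH]c3ccc(CN4CCC(C(C)(C)O)CC4)cc32)CC1`) stands at 72 mL.min-1.g-1 within the usual scatter of compound 1, although the two differ in more than one place. Compound 3 (`CC(C)NC(=O)[C@H]1CC[C@@H](n2/c(=N/C(=O)c3ccccc3)[nH]c3ccc(CN4CCC(C(C)(C)O)CC4)cc32)CC1`) has not yet been measured. It departs from compound 2 in a single place, with hydrogen in place of cyano on an aromatic carbon, which turns 3-cyanophenyl into phenyl and (3-cyanophenyl)carbonyl into benzoyl. For the measured compounds named here, no measured pair shows this change on its own, so its size cannot be read directly from the data. No step beyond the scatter is nevertheless expected in this assay here, since the benzoyl that compound 3 would carry already stands in compound 1 at 85 mL.min-1.g-1 and that value sits within the scatter of compound 2, which bears the cyano group. The estimate is a 1.1-fold lower number from compound 2 to compound 3 (0.02 log units; within the scatter) and stays inside that scatter. For compound 3 the expected intrinsic clearance in microsomes is 68 mL.min-1.g-1 (estimated range 40 mL.min-1.g-1 to 115 mL.min-1.g-1).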

Compound 3, intrinsic clearance in microsomes: 40 mL.min-1.g-1
The estimate for compound 3 lay 1.7-fold (0.23 log units) above the measured number; the measured number falls inside the stated range.
By their numbers in this assay, from the lowest: compounds 3, 2 and 1 (each within the scatter of the next, the first and the last beyond it).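

For the compounds shown here, compound 3 gives the first direct reading of this change, with every other part of compound 2 held in place. In this assay, putting hydrogen in place of cyano on an aromatic carbon of a six-membered aromatic ring of carbon only, meta to a large group, gives a 1.8-fold lower number from compound 2 to compound 3 (0.26 log units; within the scatter) and so turns (3-cyanophenyl)carbonyl into benzoyl without a step that can be told apart from repeat-measurement noise, which means that this single pair gives no sign that the cyano group sets the clearance of this compound in either direction. Nothing at hand bears on why this step has the size it has.

The compounds shown leave open how a fluorine atom, a methoxy group, an amine or a carboxylic acid would read on this same aromatic carbon, where only cyano and hydrogen appear so far. They also leave open whether the same exchange of cyano for hydrogen would read alike on a different background, such as one carrying the methyl ester and the plain piperidine of compound 1.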